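The source may report more compounds than this note shows. Statements on the series, on what has been measured and on what is new or still open speak of the compounds shown alone.

Measured so far, all as limits of the assay:

compound 1 `CC(C)c1ccc(Cn2cncc2CNc2ccc(-c3nc4ccccc4s3)c(-c3ccccc3)c2)cc1` — in a toxicity assay on NIH3T3 cells (Mus musculus) for cytotoxicity, read by resazurin assay (on this read-out higher numbers stand for an effect only at larger amounts of compound and lower numbers for an effect already at smaller amounts), compound 1 gives > 1000 nM, a limit.
compound 2 `CC(C)OC(=O)c1ccc(NCc2cncn2Cc2ccc(-c3ccccc3)cc2)cc1-c1ccccc1` — in this assay compound 2 gives > 10000 nM, a limit.
compound 3 `c1ccc(-c2ccc(Cn3cncc3CNc3ccc(-c4ccccc4)c(-c4ccccc4)c3)cc2)cc1` — in this assay compound 3 gives > 10000 nM, a limit.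

Compound 3 thus stands at a limit, and the two further values shown are limits as well: one sits at the limit of > 1000 nM in this assay, at which 1 of the 3 values shown sits, and two sit at the limit of > 10000 nM in this assay, at which 2 of the 3 values shown sit. Within the data shown here, the single step between measured compounds, a step that the two limits leave unreadable from compound 2 to compound 3, runs between two limits and its size cannot be read.

Compound 4 `c1ccc(-c2ccc(Cn3cncc3CNc3ccc(-c4noc5ccccc45)c(-c4ccccc4)c3)cc2)cc1` differs from compound 3 by a group of 9 heavy atoms (7 carbon, 1 nitrogen, 1 oxygen; one five-membered aromatic ring with 2 hetero atoms, one six-membered aromatic ring of carbon only) in place of a group of 6 heavy atoms (6 carbon; one six-membered aromatic ring of carbon only), on an aromatic carbon. No measured step bears on this exchange; the only step shown is unreadable, and every value in the series so far is a limit, so no size of effect has been resolved for any change.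

On these numbers compound 4 is expected to remain at a limit, with an estimate of 30000 nM (range 10000 nM to 100000 nM). The expected step that the limit leaves unreadable from compound 3 to compound 4 is accordingly one of no change beyond the scatter.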

Compound 4, half-maximal effective concentration: > 10000 nM
Compound 4 was reported as a limit (the forecaster's own chance of this, stated with the estimate: 85%); the middle value is on the limit's open side.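

Compound 4 gives > 10000 nM in this assay, a limit. The steps to compound 4 from compound 2 and from compound 3 run between limits, so neither can be read. The compounds shown leave open what size of effect, if any, each of these exchanges has in this assay.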